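From 3-nitrophenyl to 4-cyanophenyl on a shared core

The source may report more compounds than this note shows. Statements on the series, on what has been measured and on what is new or still open speak of the compounds shown alone.

In a functional assay on HeLa cells (Homo sapiens) for cytotoxicity, read by MTT assay, with a stated time of 24 h (on this read-out higher numbers stand for weaker inhibition and lower numbers for stronger inhibition), compound 3 (`COc1cc(/C=C2\CN(C)C/C(=C\c3cccc([N+](=O)[O-])c3)C2=O)cc(OC)c1OC`) gives 5540 nM and compound 1 (`COc1cc(/C=C2\CN(C)C/C(=C\c3ccc(F)cc3)C2=O)cc(OC)c1OC`) gives 7250 nM, two values within the scatter of each other. Compound 2 (`COc1cc(/C=C2\CN(C)C/C(=C\c3ccc(Cl)cc3Cl)C2=O)cc(OC)c1OC`) returns > 20000 nM, which is a limit of the assay and not a number.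

Compound 4 (`COc1cc(/C=C2\CN(C)C/C(=C\c3ccc(C#N)cc3)C2=O)cc(OC)c1OC`) keeps the shared core and changes one group: 4-cyanophenyl in place of 3-nitrophenyl on a double-bonded chain carbon bound to a double-bonded ring carbon.

Three measured steps changed this same place. Putting 3-nitrophenyl in place of 4-fluorophenyl gave a 1.3-fold lower number from compound 1 to compound 3 (0.12 log units; within the scatter) as its result. The two steps beyond the scatter, an at least 2.7-fold higher number from compound 1 to compound 2 (0.44 log units; beyond the scatter) and an at least 3.6-fold lower number from compound 2 to compound 3 (0.55 log units; beyond the scatter), both involve the 2,4-dichlorophenyl group, which compound 4 lacks. The estimated step is a 1.1-fold higher number from compound 3 to compound 4 (0.03 log units; within the scatter) in this assay, so no change beyond the scatter is expected. For compound 4 the estimate is 6000 nM, with 2500 nM to 14000 nM as the expected range.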

Compound 4, half-maximal inhibitory concentration: 3420 nM
Compound 4: middle estimate off by 1.8-fold (0.24 log units), on the high side, within the range that was stated.
By their numbers in this assay, from the lowest: compounds 4, 3 and 1 (each within the scatter of the next, the first and the last beyond it). At a limit, above all of these: compound 2.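

Among the compounds with a measured number at this place, the change from fluoro to cyano gives the first step beyond the scatter: a 2.1-fold lower number from compound 1 to compound 4 (0.33 log units; beyond the scatter). Replacing 3-nitrophenyl gives a 1.6-fold lower number from compound 3 to compound 4 (0.21 log units; within the scatter), so 4-cyanophenyl and 3-nitrophenyl cannot be told apart in this assay, although they differ in their atoms and in where the group sits in the name. Replacing 2,4-dichlorophenyl gives an at least 5.8-fold lower number from compound 2 to compound 4 (0.76 log units; beyond the scatter), and because compound 2 is held at a limit and not a number, that step has no upper size: the limit of > 20000 nM in this assay, at which 1 of the 4 values shown sits.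

Going by these compounds, what remains open is whether 3-cyanophenyl would read like 4-cyanophenyl, which would separate the nitrile from the place it occupies on the ring. On these data alone, how a phenyl ring carrying an amine or a carboxylic acid would read at this position also remains unknown.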